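Swapping an Ester Side Chain for Isopropyl

A few compounds are considered here, and "the series" means these few. Any claim that something is new, unique, unknown or untested is made for them only; others in the source may bear on it.

Compound 1, `CC[C@H](C)[C@@H](NC(=O)Cn1cc(C2=C(c3c[nH]c4ccccc34)C(=O)N(C)C2=O)c2ccccc21)C(=O)OC`: in a functional assay on MCF7 cells (Homo sapiens) for cytotoxicity, read by MTT assay, with a stated time of 24 h (a lower number here means a stronger inhibitor, a higher number a weaker inhibitor), compound 1 gives > 100000 nM, which is a limit of the assay rather than a number.
Compound 2, `COC(=O)CCNC(=O)Cn1cc(C2=C(c3c[nH]c4ccccc34)C(=O)N(C)C2=O)c2ccccc21`: in this assay compound 2 gives 47800 nM.
Compound 3, `COC(=O)CC[C@@H](NC(=O)Cn1cc(C2=C(c3c[nH]c4ccccc34)C(=O)N(C)C2=O)c2ccccc21)C(=O)OC`: in this assay compound 3 gives 23400 nM.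

Compound 3 holds the lowest of the two numbers obtained; its nearest neighbour is compound 2, and the step of a 2.0-fold lower number from compound 2 to compound 3 (0.31 log units; beyond the scatter) goes with 1,3-bis(methoxycarbonyl)propyl in place of 2-(methoxycarbonyl)ethyl on an amide-type nitrogen. Compound 1 reached only a limit, (the limit of > 100000 nM in this assay, at which 1 of the 3 values shown sits), so both an at least 2.0-fold lower number from compound 1 to compound 2 (0.32 log units; beyond the scatter) and an at least 4.2-fold lower number from compound 1 to compound 3 (0.63 log units; beyond the scatter) describe steps of at least modest size from that limit down to a number.

Compound 4, `COC(=O)[C@@H](CC(C)C)NC(=O)Cn1cc(C2=C(c3c[nH]c4ccccc34)C(=O)N(C)C2=O)c2ccccc21`, differs from compound 3 in one place: isopropyl in place of (methoxycarbonyl)methyl on a saturated chain carbon, two bonds along the chain from an amide-type nitrogen and a carbonyl carbon. This moves the side chain away from an ester and back toward plain alkyl, the opposite direction to the step from compound 1 to compound 3, where an at least 4.2-fold lower number from compound 1 to compound 3 (0.63 log units; beyond the scatter) went with 2-(methoxycarbonyl)ethyl replacing sec-butyl. Compound 4 keeps one methoxycarbonyl, so the reversal is partial. A higher number in this assay is therefore expected, of modest size, a 2.6-fold higher number from compound 3 to compound 4 (0.41 log units; beyond the scatter). Compound 4 is estimated at about 60000 nM, within a range from 25000 nM to 150000 nM, with a real chance that only a limit is reported.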

Compound 4, half-maximal inhibitory concentration: 37400 nM
Compound 4: the middle estimate sits 1.6-fold (0.21 log units) above what was measured; low and high end bracket the measured number.
By their numbers in this assay, from the lowest: compounds 3, 4 and 2 (each within the scatter of the next, the first and the last beyond it). At a limit, above all of these: compound 1.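

In this assay, losing the side-chain methoxycarbonyl at this position has no effect that can be told from the scatter: there is a 1.6-fold higher number from compound 3 to compound 4 (0.20 log units; within the scatter), and compound 4 is just as close to the unbranched ester side chain, with a 1.3-fold lower number from compound 2 to compound 4 (0.11 log units; within the scatter). The more telling change is among the plain alkyl side chains, where there is an at least 2.6-fold lower number from compound 1 to compound 4 (0.42 log units; beyond the scatter), so a side-chain ester is not needed to get a number below the limit, and exchanging sec-butyl for isobutyl on this carbon is enough. Compound 1 gives a limit and not a number, so the true size of that step stays unknown: the limit of > 100000 nM in this assay, at which 1 of the 4 values shown sits.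

Compound 4 also lies within the scatter of both compound 2 and compound 3, although those two are separated by a modest step, so the side chains shown do not yet give a clear order around it. Going by these compounds, what remains open is how a free carboxylic acid, an amine or a longer unbranched alkyl chain on this carbon would behave, and whether any of them would give a much lower number than these.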